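The source may hold more compounds than are shown below. What is called first, only, known or untested is meant among the compounds shown, and "the series" means these compounds.

Of the compounds shown here, two with a shared core have been read in a functional assay on HL-60 cells (Homo sapiens) for inhibition, read by MTT assay, with a stated time of 72 h; on this read-out higher numbers stand for weaker inhibition and lower numbers for stronger inhibition. Compound 1 `Cc1ccc(N2CCN(C(=O)c3oc(C)nc3-c3ccccc3)CC2)cc1`, with 4-methylphenyl on the ring amine nitrogen, gives > 1000 nM, which is a limit of the assay and not a number. Among the compounds with values here, compound 2 `COc1cccc(N2CCN(C(=O)c3oc(C)nc3-c3ccccc3)CC2)c1`, with 3-methoxyphenyl there, gives 34.8 nM, the only true number available so far. Between the two lies an at least 28-fold lower number from compound 1 to compound 2 (1.45 log units; beyond the scatter), and its size rests on (the limit of > 1000 nM in this assay, at which 1 of the 2 values shown sits).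

Compound 3 `CCOc1cccc(N2CCN(C(=O)c3oc(C)nc3-c3ccccc3)CC2)c1` departs from compound 2 in one place: methyl in place of hydrogen on a saturated chain carbon bound to an oxygen on an aromatic ring. This turns methoxy to ethoxy and 3-methoxyphenyl to 3-ethoxyphenyl. Within the data shown here, only one measured step bears on this change, the large at least 28-fold lower number from compound 1 to compound 2 (1.45 log units; beyond the scatter). It concerns the same aryl substituent, so the read-out can respond sharply there, but that exchange is much broader than the lengthening of methoxy to ethoxy. A small move towards a higher number is therefore expected in this assay, quite possibly none beyond the scatter. The estimated step is a 1.4-fold higher number from compound 2 to compound 3 (0.16 log units; within the scatter). For compound 3 the estimate is 50 nM, with an expected range from 15 nM to 200 nM.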

Compound 3, half-maximal inhibitory concentration: 151 nM
The estimate for compound 3 lay 3.0-fold (0.48 log units) below the measured number, and the stated range covers the measured number.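

The added methyl on a saturated chain carbon bound to an oxygen on an aromatic ring is a far smaller change than the exchange of aryl groups that came before it, yet in this assay it still moves the read-out, with a 4.3-fold higher number from compound 2 to compound 3 (0.64 log units; beyond the scatter). This shows that the read-out at this position responds to the lengthening of methoxy to ethoxy alone, and not only to a broad exchange of the whole aryl substituent. At the same time, 3-ethoxyphenyl keeps a clear lead over 4-methylphenyl, with an at least 6.6-fold lower number from compound 1 to compound 3 (0.82 log units; beyond the scatter), and how large that lead really is stays unknown, since compound 1 stands at a limit of the assay and not at a number: the limit of > 1000 nM in this assay, at which 1 of the 3 values shown sits.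

On these data alone, it remains open whether a longer chain such as propoxy would push the number further up in this assay, or whether a hydroxy group or a fluorine atom would read closer to compound 2. The step from compound 1 to compound 2 also changes both the group and its place on the phenyl ring at once, and the compounds shown do not separate these two changes.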